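Trimming an Ethyl to a Methyl on a Pyrazolidinone

The compounds below may be only part of what the source reports. "The series", "measured", "known", "first", "only" and "open" are said of these compounds alone.

Measured compounds:
Compound 1 `C=C1C(=O)N(c2ccccc2)N(c2ccccc2)C1C`, in a functional assay on MCF7 cells (Homo sapiens) for inhibition, read by MTT assay, with a stated time of 48 h (a higher number here means a weaker inhibitor, a lower number a stronger inhibitor), compound 1 gives 12500 nM.
Compound 2 `C=C1C(=O)N(c2ccccc2)N(C)C1CC`, in this assay compound 2 gives 185000 nM.

Of these two numbers, compound 2 holds the higher one, and the gap to compound 1 lies well beyond the scatter of repeated measurements, so compound 2 is the weaker inhibitor of the pair. Compound 3 `C=C1C(=O)N(c2ccccc2)N(C)C1C` differs from compound 2 in one place: hydrogen in place of methyl on a saturated chain carbon bound to a saturated ring carbon. Read one bond further out, the ethyl of compound 2 becomes a methyl. Compound 1 also carries a methyl there, but it differs from compound 2 in a second place as well, so its value cannot be laid on this single change. Going by the values given here, with no measured pair showing this step on its own, a small shift is expected in this assay, if any, with the direction open. For compound 3 the estimated value is 120000 nM, within 40000 nM to 400000 nM, which would mean an expected step of a 1.5-fold lower number from compound 2 to compound 3 (0.19 log units; within the scatter).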

Compound 3, half-maximal inhibitory concentration: 153000 nM
Compound 3: the middle estimate sits 1.3-fold (0.11 log units) below what was measured, within the range that was stated.
By their numbers in this assay, from the lowest: compound 1; then compounds 3 and 2 (each within the scatter of the next).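

In this assay, trimming the ethyl to a methyl gives a 1.2-fold lower number from compound 2 to compound 3 (0.08 log units; within the scatter), so this position does not separate these two groups: the change lies within the scatter of repeated measurements. The large gap appears at another place, since with the methyl held constant, methyl in place of phenyl on an amine nitrogen in a ring gives a 12-fold higher number from compound 1 to compound 3 (1.09 log units; beyond the scatter) and this single change can now be read on its own, which the first two compounds did not allow. Nothing available here explains either result. As far as these compounds go, what remains open is whether a longer chain such as propyl, or a group such as an amine or a carboxylic acid, would behave like ethyl and methyl at this position. From the compounds shown here alone, it is also open whether benzyl on the same ring nitrogen would read closer to phenyl or to methyl.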